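Toward a cyano-methoxyphenyl ether on the shared core

The compounds below may be only part of what the source reports. "The series", "measured", "known", "first", "only" and "open" are said of these compounds alone.

The shared core of compound 1 `Cc1cc(C#N)cc(C)c1Oc1nc(Nc2ccc(C#N)cc2)nc2ccccc12` carries a dimethyl-substituted aryl ether with a cyano group. In an ADME assay on MT4 cells (Homo sapiens) for cytotoxicity, read by MTT assay, with a stated time of 4 days (on this read-out lower numbers stand for higher toxicity in this test and higher numbers for lower toxicity in this test), compound 1 gives 203000 nM. Compound 2 `Cc1cc(C)c(Oc2nc(Nc3ccc(C#N)cc3)nc3ccccc23)c(C)c1` replaces that cyano with a methyl. In this assay compound 2 gives only a limit, > 34000 nM. The step that the limit leaves unreadable from compound 1 to compound 2 therefore cannot be read, because of the limit of > 34000 nM in this assay, at which 1 of the 2 values shown sits. Compound 3 `COc1cc(C#N)ccc1Oc1nc(Nc2ccc(C#N)cc2)nc2ccccc12` has not yet been measured. It differs from compound 2 by 4-cyano-2-methoxyphenyl in place of 2,4,6-trimethylphenyl on an oxygen on an aromatic ring. Within the data shown here, no measured step bears directly on this change; the only comparison at hand, from compound 1 to compound 2, is unreadable. What can be said is that compound 1, which also carries a cyano on this ring, sits at 203000 nM, so compound 3 is expected to show similarly low toxicity. For compound 3 the expected value in this assay is 150000 nM, within 40000 nM to 300000 nM. This means an expected step that the limit leaves unreadable from compound 2 to compound 3, which cannot be judged against the scatter since compound 2 stands only at a limit.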

Compound 3, half-maximal cytotoxic concentration: >= 140000 nM
Compound 3: a limit, no number; the forecaster's own chance of this, stated with the estimate: 40%; the middle value is on the limit's open side.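

In this assay, among these compounds, compound 3 gives >= 140000 nM as a limit, not a number, so no step linking it to compound 1 or compound 2 can be read. The compounds shown leave open where the true values of compound 2 and compound 3 lie, and so how all three compounds rank.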